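This account rests on a few compounds, and the source may have more. Where it says the series, first, only, none or still open, it means among the compounds named here.

In an in vitro functional assay on cells for agonist activity at Bombesin receptor subtype-3 (Mus musculus), read by luminescence and calcium flux (on this read-out lower numbers stand for an effect already at smaller amounts and higher numbers for an effect only at larger amounts of compound), compound 2, `O=C(O)c1ccccc1-c1ccc(CCc2ncc(CC3CCCC3)[nH]2)cc1`, gives 7.9 nM. For the measured compounds named here, only one other compound has been measured there: compound 1, `CCCCc1cnc(CCCc2ccc(-c3ccccc3C(=O)O)cc2)[nH]1`, which in this assay gives 382 nM, a markedly higher number that lies well beyond the scatter of repeated runs. Compound 2 therefore holds the lowest number of the two that are known.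

Compound 3, `Cc1cccc(Cc2cnc(CCc3ccc(-c4ccccc4C(=O)O)cc3)[nH]2)c1`, has not yet been measured. It differs from compound 2 in one place: 3-methylphenyl in place of cyclopentyl on a saturated chain carbon bound to an aromatic carbon. Going by the values given here, no directly comparable pair of measured compounds shows the effect of such a swap, so the direction of the step is open. The expectation is that compound 3 stays fairly close to compound 2, with a modest shift toward a higher number that may or may not exceed the scatter, a step estimated as a 3.2-fold higher number from compound 2 to compound 3 (0.50 log units; beyond the scatter). On that basis compound 3 is expected to give about 25 nM in this assay, within a range from 6 nM to 100 nM.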

Compound 3, half-maximal effective concentration: 75 nM
Compound 3: middle estimate off by 3.0-fold (0.48 log units), on the low side; low and high end bracket the measured number.
By their numbers in this assay, from the lowest: compound 2; then compound 3; then compound 1.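

Replacing cyclopentyl with 3-methylphenyl on the saturated chain carbon bound to an aromatic carbon gives, in this assay, a 9.5-fold higher number from compound 2 to compound 3 (0.98 log units; beyond the scatter). For the compounds shown here, this is the first single-place comparison, and it shows that the read-out responds to the group at this position. The aromatic ring still leaves compound 3 at a lower number than compound 1 has, but compound 3 and compound 1 differ in more than one place, so that gap says nothing about this change. No measurement at hand accounts for the size or direction of the step.

The compounds shown leave open whether the rise goes with the aromatic ring itself or with its methyl group, which a plain benzyl or a cyclohexylmethyl group at this place could separate. As far as these compounds go, how an amine or a hydroxyl on this group would read also remains unknown.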